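A few compounds are considered here, and "the series" means these few. Any claim that something is new, unique, unknown or untested is made for them only; others in the source may bear on it.

Compound 1 `CN(C)CC(=O)NCC(=O)N(C)c1ccc(Cl)cc1C(=O)c1ccccc1Cl`: 2.6 mg/kg
Compound 2 `CN(C(=O)CNC(=O)CN)c1ccc(Cl)cc1C(=O)c1ccccc1Cl`: 0.58 mg/kg
Compound 3 `CCCCCC(=O)NCC(=O)N(C)c1ccc(Cl)cc1C(=O)c1ccccc1Cl`: 1.9 mg/kg

All three were tested in a functional assay on the whole organism for antagonist activity, with Mus musculus as the target; on this read-out higher numbers stand for an effect only at larger amounts of compound and lower numbers for an effect already at smaller amounts. Compound 3 holds the second highest number of the three: its nearest neighbour is compound 1, with a 1.4-fold lower number from compound 1 to compound 3 (0.14 log units; within the scatter), and its furthest is compound 2, with a 3.3-fold higher number from compound 2 to compound 3 (0.52 log units; beyond the scatter). Compound 4 `CN1CCN(CC(=O)NCC(=O)N(C)c2ccc(Cl)cc2C(=O)c2ccccc2Cl)CC1` has not been measured. Its change from compound 3 is 4-methylpiperazin-1-yl in place of butyl on a saturated chain carbon bound to a carbonyl carbon. Within the data shown here, the steps that bear on it are a 1.4-fold lower number from compound 1 to compound 3 (0.14 log units; within the scatter) and a 3.3-fold higher number from compound 2 to compound 3 (0.52 log units; beyond the scatter), each exchanging a nitrogen-carrying group for butyl. The entering group again carries nitrogen, so a move back toward the number of compound 1, at most within the scatter, is expected, giving a 1.3-fold higher number from compound 3 to compound 4 (0.12 log units; within the scatter) in this assay. Compound 4 is therefore estimated at 2.5 mg/kg, ranging from 0.8 mg/kg to 7 mg/kg.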

Compound 4, dose for half-maximal effect: 59 mg/kg
Estimate against measurement, compound 4: 24-fold (1.37 log units) below; the measured number lies above the stated range.
By their numbers in this assay, from the lowest: compound 2; then compounds 3 and 1 (each within the scatter of the next); then compound 4.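

In this assay the earlier groups at this saturated chain carbon differed at most modestly, but 4-methylpiperazin-1-yl brings a large jump against each of them (a 31-fold higher number from compound 3 to compound 4 (1.49 log units; beyond the scatter); a 23-fold higher number from compound 1 to compound 4 (1.36 log units; beyond the scatter); a 100-fold higher number from compound 2 to compound 4 (2.01 log units; beyond the scatter)). Carrying nitrogen therefore does not by itself keep the number low, since this group carries nitrogen as amino and dimethylamino do, yet stands far from both. Nothing measured here accounts for the jump. From the compounds shown here alone, whether the ring or its methyl matters remains open. Piperazin-1-yl, without the methyl, and piperidin-1-yl at this place would help separate the two.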